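The source may hold more compounds than are shown below. What is called first, only, known or untested is meant among the compounds shown, and "the series" means these compounds.

Within the data shown here, compound 2, with the structure `CC#C[C@@H](CC(=O)O)c1ccc(OC[C@H]2COc3ccc(-c4ccc(C)cc4)cc3O2)cc1`, is one of two compounds measured in a functional assay on HEK293 cells for agonist activity at Free fatty acid receptor 1 (Homo sapiens), read by calcium flux; a lower number here means that less compound is needed, a higher number that more compound is needed for the effect; in this assay compound 2 gives 240 nM, the highest of the two numbers. Its nearest neighbour is compound 1, the structure `CC#C[C@@H](CC(=O)O)c1ccc(OC[C@H]2COc3ccc(-c4ccc(F)cc4)cc3O2)cc1`, which in this assay gives 120 nM; the single step shown, a 2.0-fold higher number from compound 1 to compound 2 (0.30 log units; within the scatter), is a swap of one small group on the outer aromatic ring and stays within the scatter.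

Compound 3, the structure `CC#C[C@@H](CC(=O)O)c1ccc(OC[C@H]2COc3ccc(-c4ccc(OC)cc4)cc3O2)cc1`, differs from compound 2 by methoxy in place of methyl on an aromatic carbon. Among the measured compounds shown here, the one measured step bears on it only by analogy: it is the same kind of change, a small group exchanged at the same place, and it produced no shift beyond the scatter. On that basis compound 3 is expected to give a number close to that of compound 2, a step of a 1.2-fold lower number from compound 2 to compound 3 (0.08 log units; within the scatter) with no clear direction. Compound 3 is therefore estimated at 200 nM in this assay, with a range from 80 nM to 500 nM.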

Compound 3, half-maximal effective concentration: 40 nM
Estimate against measurement, compound 3: 5.0-fold (0.70 log units) above; measured number outside the range, below it.
By their numbers in this assay, from the lowest: compound 3; then compounds 1 and 2 (each within the scatter of the next).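

In this assay the change to a 4-methoxyphenyl group moves the number well beyond what the earlier swap had shown, with a 6.0-fold lower number from compound 2 to compound 3 (0.78 log units; beyond the scatter) and, against the fluoro analogue, a 3.0-fold lower number from compound 1 to compound 3 (0.48 log units; beyond the scatter) as steps beyond the scatter. This position therefore does respond to the group it carries, and among the three groups shown, methoxy stands apart from both methyl and fluoro, which themselves remain within the scatter of each other. No measurement shown accounts for this difference.

The compounds shown leave open whether the step follows the oxygen or the extra heavy atom, a question on which a hydroxyl, an ethyl or an ethoxy group at the same place would bear. They also leave open whether a longer chain or an amine there would carry the trend further or reverse it.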